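Swapping the Side Chain on the Amide of Compound 1

A few compounds are considered here, and "the series" means these few. Any claim that something is new, unique, unknown or untested is made for them only; others in the source may bear on it.

Among the compounds with values here, compound 1 `COc1cc(CC(C)C(=O)N2CCN(c3ccc(C(F)(F)F)cc3[C@@H](N)CC(C)C)CC2)ccc1Cl` stands as the stronger of the two compounds measured so far in an assay on HEK293 cells for displacement of a labelled ligand from Melanocortin receptor 4 (Homo sapiens) (on this read-out higher numbers stand for weaker inhibition and lower numbers for stronger inhibition), where compound 1 gives 230 nM. Compound 2 `Cc1ccc(OCC(=O)N2CCN(c3ccc(C(F)(F)F)cc3[C@@H](N)CC(C)C)CC2)c(C)c1` shares the same core but carries a (2,4-dimethylphenoxy)methyl group on the carbonyl carbon in place of the 1-(4-chloro-3-methoxybenzyl)ethyl group; in this assay compound 2 gives 4000 nM. That single exchange produced a 17-fold higher number from compound 1 to compound 2 (1.24 log units; beyond the scatter), so the group on the carbonyl carbon clearly matters for binding in this series.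

Compound 3 `CC(C)C[C@H](N)c1cc(C(F)(F)F)ccc1N1CCN(C(=O)CNc2ccccc2)CC1` has not yet been measured. It differs from compound 1 at the same place: anilinomethyl in place of 1-(4-chloro-3-methoxybenzyl)ethyl on a carbonyl carbon. Within the data shown here, the only measured step that bears on this change is the one from compound 1 to compound 2, which was large. Because compound 2 gave 4000 nM after a change at this same place, compound 3 is expected to bind more weakly than compound 1, with an estimated step of an 11-fold higher number from compound 1 to compound 3 (1.04 log units; beyond the scatter). The estimate for compound 3 in this assay is 2500 nM, with a likely range from 600 nM to 10000 nM.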

Compound 3, inhibition constant: 3600 nM
Beside the measured number, compound 3's estimate is 1.4-fold (0.16 log units) below it; the measured number falls inside the stated range.
By their numbers in this assay, from the lowest: compound 1; then compounds 3 and 2 (each within the scatter of the next).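

Within the data shown here, the second replacement confirms that this position on the carbonyl carbon is sensitive: in this assay, exchanging the 1-(4-chloro-3-methoxybenzyl)ethyl group for anilinomethyl gives a 16-fold higher number from compound 1 to compound 3 (1.19 log units; beyond the scatter), a large step of the same kind as the one seen with compound 2. The loss is therefore not tied to the 2,4-dimethylphenoxy group alone, as two different groups now both fall well short of compound 1. Those two groups also cannot be told apart, with anilino in place of 2,4-dimethylphenoxy giving a 1.1-fold lower number from compound 2 to compound 3 (0.05 log units; within the scatter), so this exchange of the ring-bearing side chain has no readable effect on binding. No measurement available here accounts for the advantage of the group in compound 1.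

On these data alone, it remains open which part of the 1-(4-chloro-3-methoxybenzyl)ethyl group matters, as its chlorine, its methoxy and its branched chain all leave together in each step. Also open, as far as these compounds go, is how this position would respond to a group without an aromatic ring, such as a longer alkyl chain, a carboxylic acid or an amine.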